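The source may hold more compounds than are shown below. What is called first, only, known or untested is meant among the compounds shown, and "the series" means these compounds.

Three compounds built on one shared core have numbers in an ADME assay on MT4 cells (Homo sapiens) for cytotoxicity, read by MTT assay, with a stated time of 96 h; on this read-out higher numbers stand for lower toxicity in this test and lower numbers for higher toxicity in this test. Compound 1 `CC(=O)c1ccc2c(c1)nc(-c1ccccc1)n2C1CCCCC1` gives 37000 nM, compound 2 `CC(=O)c1ccc2c(c1)nc(-c1ccoc1)n2C1CCCCC1` gives 63000 nM, and compound 3 `C/C(=N\NC(N)=S)c1ccc2c(c1)nc(-c1ccccc1)n2C1CCCCC1` gives 20000 nM. Compound 3 stands clearly apart only from compound 2, on the low side. Its gap to compound 1 stays within the scatter, so those two cannot be told apart here.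

Compound 4 `C/C(=N\NC(N)=S)c1ccc2c(c1)nc(-c1ccoc1)n2C1CCCCC1` differs from compound 3 in a single place: furan-3-yl in place of phenyl on an aromatic carbon. In words, furan-3-yl takes the place of phenyl on an aromatic carbon.

The same swap has already been measured once, on the partner without the longer side chain of compound 3, and it gave a 1.7-fold higher number from compound 1 to compound 2 (0.23 log units; within the scatter). That is the step that bears most directly on compound 4. The other measured step, a 1.9-fold lower number from compound 1 to compound 3 (0.27 log units; within the scatter), changes a different place on the molecule. It shows only that this side chain has not moved the number beyond the scatter, so the swap may plausibly carry over.

A small upward move, probably not beyond the scatter, is therefore expected in this assay. The estimated step is a 1.7-fold higher number from compound 3 to compound 4 (0.22 log units; within the scatter). For compound 4 the expected value is 33000 nM, with an estimated range from 16000 nM to 65000 nM.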

Compound 4, half-maximal cytotoxic concentration: 21000 nM
The estimate for compound 4 lay 1.6-fold (0.20 log units) above the measured number, and the stated range covers the measured number.
By their numbers in this assay, from the lowest: compounds 3, 4, 1 and 2 (each within the scatter of the next, the first and the last beyond it).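

In this assay, the new reading comes from the compounds carrying the longer side chain, where furan-3-yl in place of phenyl gives a 1.1-fold higher number from compound 3 to compound 4 (0.02 log units; within the scatter), so on this aromatic carbon between two ring nitrogen atoms the swap again stays within the scatter. The two readings of this swap, one on each partner, agree with each other: the same change on two cores in this assay, a 1.7-fold higher number (0.23 log units; within the scatter) from compound 1 to compound 2 and a 1.1-fold higher number (0.02 log units; within the scatter) from compound 3 to compound 4, 1.6-fold (0.21 log units) apart, within the scatter of two such steps The side-chain change, now read on the furan-3-yl partners, gives a 3.0-fold lower number from compound 2 to compound 4 (0.48 log units; beyond the scatter), which lies beyond the scatter, unlike its reading on the phenyl partners, yet the two readings of that change cannot be told apart: the same change on two cores in this assay, a 1.9-fold lower number (0.27 log units; within the scatter) from compound 1 to compound 3 and a 3.0-fold lower number (0.48 log units; beyond the scatter) from compound 2 to compound 4, 1.6-fold (0.21 log units) apart, within the scatter of two such steps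

At this position the compounds shown compare only two aromatic rings, phenyl and furan-3-yl, so they cannot tell whether a pyridine ring, a thiophene ring, or a phenyl ring bearing an amine or a carboxylic acid would shift the number beyond the scatter. As far as these compounds go, all four compounds also share the cyclohexyl group, so the effect of a smaller group there, such as methyl, or of a longer chain remains open.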